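This account rests on a few compounds, and the source may have more. Where it says the series, first, only, none or still open, it means among the compounds named here.

Measured compounds:
- compound 1 `CCCCCCCCCCCCCCC1(C(=O)OCCCC)CO1` gives 1.5 mg/kg
- compound 2 `CCCCCCCCCCCCCCC1(C(N)=O)CO1` gives 10 mg/kg
- compound 3 `CCCCCCCCCCCCCCCCCCC1(C(=O)OC)CO1` gives 10 mg/kg

These three share one core and were tested in a functional assay on the whole organism with Rattus norvegicus as the target, in the glucose tolerance test; a higher number here means that more compound is needed for the effect, a lower number that less compound is needed. Compound 3 stands at 10 mg/kg, level with compound 2 within the scatter, and together with compound 2 it carries the highest number of the three; compound 1 sits well apart at 1.5 mg/kg.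

Compound 4 `CCCCCCCCCCCCCCC1(C(=O)OC)CO1` has not yet been measured. It differs from compound 3 in one place: hydrogen in place of butyl on a saturated chain carbon, ten or more bonds along the chain from a saturated ring carbon. Within the data shown here, the only measured step, a 6.7-fold higher number from compound 1 to compound 2 (0.82 log units; beyond the scatter), concerns a change on the carbonyl carbon, not on the long chain, so it does not speak directly to this change. Among the measured compounds shown here, no pair of measured compounds shows a shortened chain alone, so the direction of the step is open. Compound 4 does share its chain length with compound 1, which gives 1.5 mg/kg, while compound 3 gives 10 mg/kg, and that is the only hint available. A step toward a lower number is therefore thought plausible but uncertain, and the estimated step is a 2.0-fold lower number from compound 3 to compound 4 (0.30 log units; within the scatter). Compound 4 is expected to give about 5 mg/kg, within a range from 1.5 mg/kg to 15 mg/kg.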

Compound 4, minimum effective dose: 4 mg/kg
Compound 4: the middle estimate sits 1.3-fold (0.10 log units) above what was measured; the range from low to high includes it.
By their numbers in this assay, from the lowest: compound 1; then compound 4; then compounds 2 and 3 (each within the scatter of the next).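

Cutting the chain alone, with hydrogen in place of butyl on a saturated chain carbon, ten or more bonds along the chain from a saturated ring carbon, gives a 2.5-fold lower number from compound 3 to compound 4 (0.40 log units; beyond the scatter) in this assay, so chain length by itself moves the dose, which no earlier pair could show. With the chain now held fixed, methoxy in place of amino on a carbonyl carbon gives a 2.5-fold lower number from compound 2 to compound 4 (0.40 log units; beyond the scatter), and hydrogen in place of propyl on a saturated chain carbon bound to an oxygen next to a carbonyl group gives a 2.7-fold higher number from compound 1 to compound 4 (0.43 log units; beyond the scatter). The group on the carbonyl carbon therefore matters in small steps as well as the large one seen earlier.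

A shorter chain than in compound 4, or a carboxylic acid in place of the ester, remains an open question. No evidence is at hand to explain any of these steps.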